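A Heptyl Chain Gives Way to Cyclohexyl

A few compounds are considered here, and "the series" means these few. Any claim that something is new, unique, unknown or untested is made for them only; others in the source may bear on it.

Compound 3 `CCCCCCC[C@H]1C[C@H](Br)CCN1S(=O)(=O)c1ccc(C)cc1` was tested in a functional assay on A2780 cells (Homo sapiens) for antiproliferative activity, read by sulforhodamine B assay, with a stated time of 48 h (a higher number here means a weaker inhibitor of growth, a lower number a stronger inhibitor of growth), and gives only a limit, > 100000 nM. Compound 2 `Cc1ccc(S(=O)(=O)N2CCC(Br)CC2)cc1` likewise reaches only a limit, > 100000 nM. The step that the two limits leave unreadable from compound 2 to compound 3 is therefore unreadable since (the limit of > 100000 nM in this assay, at which 2 of the 3 values shown sit). Compound 1 `Cc1ccc(S(=O)(=O)N2CC[C@@H](Cl)C[C@@H]2C2CCCCC2)cc1` carries the same cyclohexyl group that compound 4 will carry, with chloro in place of bromo, and in this assay compound 1 gives 72000 nM. Compound 4 `Cc1ccc(S(=O)(=O)N2CC[C@@H](Br)C[C@@H]2C2CCCCC2)cc1` differs from compound 3 by cyclohexyl in place of heptyl on a saturated ring carbon. Among the measured compounds shown here, no measured step covers this change, so the expectation rests mainly on compound 1 and its 72000 nM. Compound 4 is expected to give about 80000 nM, with a likely range from 30000 nM to 200000 nM. That expectation corresponds to an estimated step of an at least 1.2-fold lower number from compound 3 to compound 4 (0.09 log units; that floor lies within the scatter).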

Compound 4, concentration for 50% growth inhibition: > 100000 nM
Compound 4 ended at the assay's limit; the forecaster's own chance of this, stated with the estimate: 35%; middle value at least 1.2-fold (0.09 log units) from the limit.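

In this assay, bromo in place of chloro gives an at least 1.3-fold higher number from compound 1 to compound 4 (0.14 log units; that floor lies within the scatter), so the data cannot say whether the two halogens truly differ at this position. With bromo on the ring, neither heptyl nor cyclohexyl yields a readable number, and only chloro compound 1 has one. The steps from compound 2 and compound 3 to compound 4 cannot be read, because all three compounds stop at the same limit: the limit of > 100000 nM in this assay, at which 3 of the 4 values shown sit.

On these data alone, how far compound 4 truly lies from compound 1 remains open. So does whether an amine or a carboxylic acid in place of cyclohexyl would give a readable value.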